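The source may hold more compounds than are shown below. What is called first, only, known or untested is meant among the compounds shown, and "the series" means these compounds.

The series is built on a benzyl-protected sugar core. Compound 1 `CCCC[C@@H]1O[C@H](COCc2ccccc2)[C@@H](OCc2ccccc2)[C@H](OCc2ccccc2)[C@H]1O` is reported as "not active" (no number reported) in a functional assay on HL-60 cells (Homo sapiens) for antiproliferative activity, read by MTT assay; a lower number here means a stronger inhibitor, a higher number a weaker inhibitor. Compound 2 `O[C@H]1CO[C@H](COCc2ccccc2)[C@@H](OCc2ccccc2)[C@@H]1OCc1ccccc1` likewise gives "not active" (no number reported) in this assay; no number places it against the others, and compound 1 also carries no number. Among the compounds with values here, compound 3 `OCCC[C@@H]1O[C@H](COCc2ccccc2)[C@@H](OCc2ccccc2)[C@H](OCc2ccccc2)[C@H]1O` gives 19300 nM in this assay, the only number in the set. Compound 4 `CCCC[C@H]1O[C@H](COCc2ccccc2)[C@@H](OCc2ccccc2)[C@H](OCc2ccccc2)[C@H]1O` differs from compound 2 by butyl in place of hydrogen on a saturated ring carbon. Within the data shown here, no step between measured compounds is available, so the size of this change in this assay cannot be drawn from the data; since compound 1 shows "not active" (no number reported) with a butyl chain on the same core, no gain beyond the scatter is expected. Compound 4 is expected to give about 50000 nM, ranging from 15000 nM to 200000 nM.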

Compound 4, half-maximal inhibitory concentration: "not active" (no number reported)
For compound 4 the study gives words and no number; there is nothing to compare the estimate with.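

Compound 2 and compound 4 both carry words rather than numbers in this assay, and no new step can be read from them. The compounds shown leave open whether configuration at the butyl-bearing carbon affects activity, with neither butyl compound giving a number: the fact that compounds 1 and 4 differ only in the configuration as drawn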